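Swapping the bicyclic amide substituent in a CXCR3 antagonist series

The source may report more compounds than this note shows. Statements on the series, on what has been measured and on what is new or still open speak of the compounds shown alone.

Three compounds sharing one core differ only in the bicyclic group attached on a saturated chain carbon bound to a carbonyl carbon. In a functional assay on U2OS cells for antagonist activity at C-X-C chemokine receptor type 3 (Homo sapiens), read by beta-arrestin recruitment (on this read-out higher numbers stand for weaker inhibition and lower numbers for stronger inhibition), compound 1 `CCOc1ncc(-c2nc(C(F)(F)F)sc2N2CCN(C(=O)Cn3cnc4cccnc43)[C@H](C)C2)cn1` gives 20 nM, compound 2 `CCOc1ncc(-c2nc(C(F)(F)F)sc2N2CCN(C(=O)Cn3cnc4ccccc43)[C@H](C)C2)cn1` gives 49 nM, and compound 3 `CCOc1ncc(-c2nc(C(F)(F)F)sc2N2CCN(C(=O)Cn3ccc4cnccc43)[C@H](C)C2)cn1` gives 23 nM. Compound 3 thus stands second highest of the three: its number sits within the scatter of compound 1, while the step of a 2.1-fold lower number from compound 2 to compound 3 (0.33 log units; beyond the scatter) lies beyond it. The other steps are a 2.5-fold higher number from compound 1 to compound 2 (0.39 log units; beyond the scatter) and a 1.2-fold higher number from compound 1 to compound 3 (0.06 log units; within the scatter).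

Compound 4 `CCOc1ncc(-c2nc(C(F)(F)F)sc2N2CCN(C(=O)Cn3c(=O)oc4ccccc43)[C@H](C)C2)cn1` carries the change (a group of 10 heavy atoms (7 carbon, 1 nitrogen, 2 oxygen; one five-membered aromatic ring with 2 hetero atoms, one six-membered aromatic ring of carbon only) in place of a group of 9 heavy atoms (7 carbon, 2 nitrogen; one five-membered aromatic ring with 1 hetero atom, one six-membered aromatic ring with 1 hetero atom), on a saturated chain carbon bound to a carbonyl carbon). The entering group shares with the group of compound 2 a six-membered aromatic ring of carbon only and a five-membered aromatic ring with 2 hetero atoms, so the step of a 2.1-fold lower number from compound 2 to compound 3 (0.33 log units; beyond the scatter) run backwards is the closest guide, while the step of a 2.5-fold higher number from compound 1 to compound 2 (0.39 log units; beyond the scatter) points the same way. Nothing in the three compounds tells how the two oxygen atoms and the double bond outside aromatic rings will read out, so the direction is uncertain. Compound 4 is therefore expected to show a modest step upward, a 2.0-fold higher number from compound 3 to compound 4 (0.29 log units; within the scatter), and its value in this assay is estimated at 45 nM, within a range of 15 nM to 150 nM.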

Compound 4, half-maximal inhibitory concentration: 99 nM
Compound 4: middle estimate off by 2.2-fold (0.34 log units), on the low side; low and high end bracket the measured number.
By their numbers in this assay, from the lowest: compounds 1 and 3 (each within the scatter of the next); then compound 2; then compound 4.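

At the saturated chain carbon bound to a carbonyl carbon, this assay now shows a wider span than the first three groups revealed: the group with 2 oxygen atoms and 1 double bond outside aromatic rings gives a 4.3-fold higher number from compound 3 to compound 4 (0.63 log units; beyond the scatter) and a 5.0-fold higher number from compound 1 to compound 4 (0.69 log units; beyond the scatter), both larger than any step among compounds 1, 2 and 3. The group of compound 2 also has a six-membered aromatic ring of carbon only, yet a 2.0-fold higher number from compound 2 to compound 4 (0.31 log units; beyond the scatter) still follows, so sharing that ring type does not make the two groups read out alike. With all three of its steps beyond the scatter, compound 4 is the weakest of the four, and no measurement is at hand that would explain this result.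

The compounds shown leave open whether the two oxygen atoms or the double bond outside aromatic rings carries the step, as these arrive together in compound 4 and no compound here separates them. Also open, from the compounds shown here alone, is how a phenyl group in place of the bicyclic group, or a bicyclic group bearing an amine or a carboxylic acid, would read out at this place.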